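Furan-linked aminoquinoline series: solubility notes, compound 3

A few compounds are considered here, and "the series" means these few. Any claim that something is new, unique, unknown or untested is made for them only; others in the source may bear on it.

Compound 2 `CC(C)(C)c1ccc(-c2ccc3c(NCCCNCc4ccco4)ccnc3c2)cc1` holds the higher of the two numbers in a physicochemical assay for solubility, with a stated time of 18 h, at pH 7.4 (a higher number here means a more soluble compound, a lower number a less soluble compound), where compound 2 gives 32000 nM; compound 1 `COc1cccc(Oc2ccc3c(NCCCNCc4ccco4)ccnc3c2)c1` gives 14500 nM. Compound 3 `COc1ccccc1Oc1ccc2c(NCCCNCc3ccco3)ccnc2c1` is not yet measured. The change: 2-methoxyphenoxy in place of 4-(tert-butyl)phenyl on an aromatic carbon. Going by the values given here, the only step that bears on it is a 2.2-fold higher number from compound 1 to compound 2 (0.34 log units; beyond the scatter), which ran from a methoxyphenoxy group to the group that now leaves. Reversing that direction, the expected step is a 2.1-fold lower number from compound 2 to compound 3 (0.33 log units; beyond the scatter), a modest decrease because compound 1 gives 14500 nM. Compound 3 is therefore estimated at 15000 nM, with a range from 6000 nM to 40000 nM.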

Compound 3, solubility: 14500 nM
Estimate against measurement, compound 3: 1.0-fold (0.01 log units) above; measured number inside the range.
By their numbers in this assay, from the lowest: compounds 1 and 3 (each within the scatter of the next); then compound 2.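

In this assay, 2-methoxyphenyl in place of 3-methoxyphenyl on the oxygen gives no change at the digits printed from compound 1 to compound 3 (within the scatter) and so does not separate the two methoxyphenoxy compounds. 2-methoxyphenoxy in place of 4-(tert-butyl)phenyl gives a 2.2-fold lower number from compound 2 to compound 3 (0.34 log units; beyond the scatter) and so the gap to compound 2 no longer rests on compound 1 alone. Nothing at hand accounts for either step. This change swaps the oxygen link and the ring substituent together, and the compounds shown do not separate the two. Also open, from the compounds shown here alone, is how a carboxylic acid or a morpholine on the aryl ring at this position would read.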